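The compounds below may be only part of what the source reports. "The series", "measured", "known", "first", "only" and "open" are said of these compounds alone.

Of the compounds shown here, three have so far been tested in a functional assay on HeLa cells (Homo sapiens) for inhibition, read by MTT assay, with a stated time of 48 h; on this read-out higher numbers stand for weaker inhibition and lower numbers for stronger inhibition. Compound 1 (`CN(C)c1ccc(C(c2c[nH]c3ccc(Br)cc23)c2c[nH]c3ccc(Br)cc23)cc1`) gives 12800 nM. Compound 2 (`CCCCCCCC(c1c[nH]c2ccc([N+](=O)[O-])cc12)c1c[nH]c2ccc([N+](=O)[O-])cc12`) gives 35000 nM. Compound 3 (`OC[C@H]1O[C@@H](n2cc(C(c3ccc(Cl)cc3)c3cn([C@@H]4O[C@H](CO)[C@@H](O)[C@H](O)[C@H]4O)c4ccc(Br)cc34)c3cc(Br)ccc32)[C@H](O)[C@@H](O)[C@@H]1O`) gives 32000 nM. The numbers for compound 3 and compound 2 lie within the usual scatter of repeated measurements, so they cannot be told apart. The number for compound 1 is lower than that of compound 3 by more than the scatter, which on this read-out means stronger inhibition.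

Compound 4 (`OC[C@H]1O[C@@H](n2cc(C(c3ccc(Br)cc3)c3cn([C@@H]4O[C@H](CO)[C@@H](O)[C@H](O)[C@H]4O)c4ccc(Br)cc34)c3cc(Br)ccc32)[C@H](O)[C@@H](O)[C@@H]1O`) has not yet been measured. It differs from compound 3 in one place: bromo in place of chloro on an aromatic carbon. In words, this is bromo in place of chloro on an aromatic carbon, para to a large group, or 4-chlorophenyl to 4-bromophenyl when cut one bond further out.

For the measured compounds named here, no two measured compounds differ in just one place, so the data give no direct guide to the size of this swap. With so small a change, no step beyond the scatter is expected in this assay, and no direction is favoured. The best starting point is therefore compound 3 at 32000 nM. The estimated change is a 1.1-fold lower number from compound 3 to compound 4 (0.03 log units; within the scatter), which stays within the scatter. For compound 4 the estimated value is 30000 nM, with an expected range of 15000 nM to 60000 nM.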

Compound 4, half-maximal inhibitory concentration: 27000 nM
Compound 4: the middle estimate sits 1.1-fold (0.05 log units) above what was measured; the range from low to high includes it.
By their numbers in this assay, from the lowest: compound 1; then compounds 4, 3 and 2 (each within the scatter of the next).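

This is the only pair shown so far that differs in a single place, and in this assay the exchange of 4-chlorophenyl for 4-bromophenyl gives a 1.2-fold lower number from compound 3 to compound 4 (0.07 log units; within the scatter). At this position, on an aromatic carbon para to a large group, chloro and bromo therefore cannot be told apart on this read-out, so swapping one of these halogens for the other gives no measurable handle on inhibition in these cells. No separate measurement is at hand that bears on this result, so the data offer no account of why the two compounds match.

As far as these compounds go, what remains open is whether this position responds to anything other than these two halogens: a methoxy group, an amine or a carboxylic acid in the same place would test this far more strictly than one halogen in place of another. It also remains unknown what the sugar groups on the shared core contribute, as no compound shown differs from compound 4 in that one respect alone.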